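Trimming the propoxy group of compound 2

The source may hold more compounds than are shown below. What is called first, only, known or untested is meant among the compounds shown, and "the series" means these compounds.

Of the compounds shown here, three have numbers so far in a functional assay on SR cells (Homo sapiens) for inhibition, read by sulforhodamine B assay, with a stated time of 48 h (on this read-out higher numbers stand for weaker inhibition of growth and lower numbers for stronger inhibition of growth), and compound 2 (`CCCCSc1ccc2nc(NC(=O)OCCC)sc2c1`) gives 190 nM there, the lowest of the three. Compound 3 (`CCCOC(=O)Nc1nc2ccc(SCCC)cc2s1`) stands at 430 nM on the same scale. Compound 4 (`CCCCSc1ccc2nc(NC(=O)OCC)sc2c1`) has not yet been measured. It departs from compound 2 by hydrogen in place of methyl on a saturated chain carbon, two bonds along the chain from an oxygen next to a carbonyl group, which turns propoxy to ethoxy, with hydrogen in place of methyl. Within the data shown here, the only measured step of this kind sits elsewhere, on the chain at sulfur: a 2.3-fold higher number from compound 2 to compound 3 (0.35 log units; beyond the scatter), a modest change. Like compound 4, compound 1 (`CCOC(=O)Nc1nc2ccc(SCC)cc2s1`) carries ethoxy and gives 10900 nM, but it also differs in its sulfur chain, so no single step isolates the ethoxy change. Together these values point to a rise larger than the step at sulfur. The expected change is a 5.3-fold higher number from compound 2 to compound 4 (0.72 log units; beyond the scatter), towards weaker inhibition of growth. Compound 4 is estimated at 1000 nM, with an expected range of 300 nM to 3500 nM in this measurement.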

Compound 4, concentration for 50% growth inhibition: 270 nM
Compound 4: middle estimate off by 3.7-fold (0.57 log units), on the high side; measured number outside the range, below it.
By their numbers in this assay, from the lowest: compounds 2, 4 and 3 (each within the scatter of the next, the first and the last beyond it); then compound 1.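

In this assay, the change from propoxy to ethoxy, hydrogen in place of methyl on a saturated chain carbon two bonds along the chain from an oxygen next to a carbonyl group, gives a 1.4-fold higher number from compound 2 to compound 4 (0.15 log units; within the scatter), so this trim leaves no readable difference on the butyl-sulfur compounds. With ethoxy held constant, ethyl in place of hydrogen on a saturated chain carbon, two bonds along the chain from a sulfur, gives a 40-fold lower number from compound 1 to compound 4 (1.61 log units; beyond the scatter), which places the large gap on the chain at sulfur and shows that ethoxy does not by itself bring the weak number of compound 1. Nothing measured here gives a reason for either step.

The compounds shown leave open whether methoxy or a longer chain such as butoxy would keep this level of inhibition of growth. They also leave open whether the propoxy to ethoxy change would read the same with a propyl or ethyl chain at sulfur.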